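A few compounds are considered here, and "the series" means these few. Any claim that something is new, unique, unknown or untested is made for them only; others in the source may bear on it.

- Compound 1 `CCCCCCC#Cc1cn(C/C=C/CN2C(=O)c3ccccc3C2=O)c(=O)[nH]c1=O`: 28000 nM
- Compound 2 `CCCCc1ccc(C#Cc2cn(C/C=C/CN3C(=O)c4ccccc4C3=O)c(=O)[nH]c2=O)cc1`: 31000 nM
- Compound 3 `CCCCC#Cc1cn(C/C=C/CN2C(=O)c3ccccc3C2=O)c(=O)[nH]c1=O`: not yet measured

In a functional assay on CCRF-CEM cells (Homo sapiens) for antiproliferative activity, read by MTT assay, with a stated time of 3 days (a higher number here means a weaker inhibitor, a lower number a stronger inhibitor), compound 2 gives 31000 nM, which lies within the scatter of compound 1 at 28000 nM. Compound 3 keeps the shared core and carries butyl in place of 4-butylphenyl on a triple-bonded carbon. Within the data shown here, only one measured step bears on this change. Putting 4-butylphenyl in place of hexyl gave a 1.1-fold higher number from compound 1 to compound 2 (0.04 log units; within the scatter), so that swap left this assay unmoved beyond the scatter. Among the measured compounds shown here, no measured compound carries butyl itself, which leaves the expectation loose. No step beyond the scatter is therefore expected, and the estimated change is a 1.0-fold higher number from compound 2 to compound 3 (0.01 log units; within the scatter). For compound 3 the expected value is 32000 nM, within an estimated range of 14000 nM to 70000 nM.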

Compound 3, half-maximal inhibitory concentration: 192000 nM
Estimate against measurement, compound 3: 6.0-fold (0.78 log units) below; the measured number lies above the stated range.
By their numbers in this assay, from the lowest: compounds 1 and 2 (each within the scatter of the next); then compound 3.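

At the triple-bonded carbon, the substituent proves not to be indifferent in this assay: hexyl and 4-butylphenyl read alike, yet butyl gives a 6.2-fold higher number from compound 2 to compound 3 (0.79 log units; beyond the scatter) and, set against hexyl, a 6.9-fold higher number from compound 1 to compound 3 (0.84 log units; beyond the scatter). Both steps run the same way, so the flat first step had hidden a sensitivity at this place, and among these three compounds, compound 3, with the shortest group, is the weakest. Nothing available explains why the loss of the ethyl end of the chain, or the exchange of 4-butylphenyl for butyl, has this effect.

As far as these compounds go, what a longer chain such as octyl would do at this carbon remains open, and so does whether the response to chain length is gradual or abrupt between butyl and hexyl. Whether phenyl without its butyl tail, or a chain ending in an amine, would behave like 4-butylphenyl or like butyl also remains unsettled.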